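Moving the chlorine on the urea-bound phenyl of a thienopyrimidine

The compounds below may be only part of what the source reports. "The series", "measured", "known", "first", "only" and "open" are said of these compounds alone.

Measured so far in a functional assay on MDA-MB-231 cells (Homo sapiens) for cytotoxicity, read by MTT assay, with a stated time of 72 h; on this read-out higher numbers stand for weaker inhibition and lower numbers for stronger inhibition:
compound 1 `CN(C)CCNc1nc(-c2ccc(NC(=O)Nc3ccc(Cl)cc3)cc2)nc2ccsc12`, 310 nM
compound 2 `CN(C)CCNc1nc(-c2ccc(NC(=O)Nc3ccc(Cl)cc3)cc2)nc2c(Cl)c(Cl)sc12`, 870 nM
compound 3 `CN(C)CCNc1nc(-c2ccc(NC(=O)Nc3ccccc3Cl)cc2)nc2ccsc12`, 550 nM

Compound 1 and compound 2 share the urea side chain but differ in the core; how the two cores differ is not broken down here. Their values show compound 2 at a higher number than compound 1, a gap beyond the usual scatter, while compound 2 and compound 3 lie within the scatter of each other.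

Compound 3 differs from compound 1 by one change, (2-chlorophenyl in place of 4-chlorophenyl on an amide-type nitrogen). That change gave a 1.8-fold higher number from compound 1 to compound 3 (0.25 log units; within the scatter).

Compound 4 `CN(C)CCNc1nc(-c2ccc(NC(=O)Nc3ccccc3Cl)cc2)nc2c(Cl)c(Cl)sc12` is not yet measured. It differs from compound 2 by 2-chlorophenyl in place of 4-chlorophenyl on an amide-type nitrogen, the same change that separates compound 1 from compound 3, made on the core of compound 2 instead of the core of compound 1. The place of the change reads the same in both pairs. Going by the values given here, with only one earlier example of this change, the expectation rests on that single step: compound 4 is expected to sit at a higher number than compound 2, with a 1.7-fold higher number from compound 2 to compound 4 (0.24 log units; within the scatter) as the estimated step, because the step of a 1.8-fold higher number from compound 1 to compound 3 (0.25 log units; within the scatter) was of that size. The value of compound 4 in this assay is estimated at 1500 nM, expected to fall between 600 nM and 3800 nM.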

Compound 4, half-maximal inhibitory concentration: 1350 nM
The estimate for compound 4 lay 1.1-fold (0.05 log units) above the measured number; measured number inside the range.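

In this assay, the change to 2-chlorophenyl on the core of compound 2 gives a 1.6-fold higher number from compound 2 to compound 4 (0.19 log units; within the scatter) and so reads much like the same change on the core of compound 1. Set side by side, the two steps show that this change carried over from one core to the other with no detectable difference in its size: the same change on two cores in this assay, a 1.8-fold higher number (0.25 log units; within the scatter) from compound 1 to compound 3 and a 1.6-fold higher number (0.19 log units; within the scatter) from compound 2 to compound 4, 1.1-fold (0.06 log units) apart, within the scatter of two such steps. This does not show that the change itself has a real effect, since each step lies within the scatter on its own; the agreement says only that no large shift appeared on either core, and two cores are too few to make a rule for the whole series.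

The compounds shown leave open whether the same carry-over would hold for a different change on that phenyl ring, such as a plain phenyl, or a bromine or a methyl group in place of the chlorine, where a step large enough to stand clear of the scatter might be easier to compare across cores. They also leave open how the change would behave with a longer chain in place of the dimethylaminoethyl side chain, or in other cell lines.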